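Sulfonyl substituent exchange on a halogenated anilinopyrimidine acrylamide

The compounds below may be only part of what the source reports. "The series", "measured", "known", "first", "only" and "open" are said of these compounds alone.

Measured compounds:
compound 1 `C=CC(=O)Nc1cc(Nc2ncc(Cl)c(Nc3ccccc3S(=O)(=O)C(C)C)n2)c(OC)cc1N(C)CCN(C)C` — 17%
compound 2 `C=CC(=O)Nc1cc(Nc2ncc(F)c(Nc3ccccc3S(=O)(=O)C(C)C)n2)c(OC)cc1N(C)CCN(C)C` — 27%
compound 3 `C=CC(=O)Nc1cc(Nc2ncc(I)c(Nc3ccccc3S(=O)(=O)C(C)C)n2)c(OC)cc1N(C)CCN(C)C` — 19%

In an ADME assay on microsomes from liver (Canis lupus familiaris) for metabolic stability, read by LC-MS, using NADPH, with a stated time of 30 min, tested at 1 uM (on this read-out higher numbers stand for a more stable compound and lower numbers for a less stable compound), compound 1 gives 17% and stands lowest of the three numbers, though the gaps to the others are small: a number 10 percentage points higher from compound 1 to compound 2 (within the scatter) and a number 2 percentage points higher from compound 1 to compound 3 (within the scatter), and between the other two a number 8 percentage points lower from compound 2 to compound 3 (within the scatter). The three compounds share one core and differ only in the halogen on the aromatic carbon, so the set as a whole sits within a narrow band.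

Compound 4 `C=CC(=O)Nc1cc(Nc2ncc(Cl)c(Nc3ccccc3S(=O)(=O)N(C)C)n2)c(OC)cc1N(C)CCN(C)C` differs from compound 1 at a different place: dimethylamino in place of isopropyl on a sulfonyl sulfur. Going by the values given here, none of the measured steps touches the sulfonyl sulfur, so no measured step bears directly on this change. What the data show is a series whose halogen swaps moved this assay only within the scatter, and nothing indicates how the group on the sulfonyl sulfur acts. The expectation for compound 4 in this assay is therefore a step of about a number 5 percentage points higher from compound 1 to compound 4 (within the scatter), with no direction claimed beyond the scatter. Compound 4 is estimated at 22%, with a range from 8% to 45%.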

Compound 4, percent of the compound remaining: 31%
For compound 4 the middle estimate is 9 percentage points below the measured one, within the range that was stated.
By their numbers in this assay, from the lowest: compounds 1, 3, 2 and 4 (each within the scatter of the next, the first and the last beyond it).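

With dimethylamino in place of isopropyl on a sulfonyl sulfur, this assay shows a number 14 percentage points higher from compound 1 to compound 4 (beyond the scatter), so this position moved the read-out beyond the scatter, which none of the halogen swaps did. The two groups match in heavy-atom count, and the exchange puts one nitrogen in place of one carbon, so a change of that limited size on the sulfonyl sulfur was enough for a modest step. Nothing available explains why the number rose with this change.

Going by these compounds alone, the change is seen only with chloro on the shared core, so whether it carries over to the fluoro and iodo compounds remains open. Going by these compounds, it is also open how other groups on the sulfonyl sulfur, such as methylamino, morpholine or a longer chain, would read in this assay.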